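From Acetyl to Benzoyl in a Cytotoxicity Series

The source may hold more compounds than are shown below. What is called first, only, known or untested is meant among the compounds shown, and "the series" means these compounds.

Compound 1: `O=C(Nc1ccccc1C(F)(F)F)C1CCc2ccccc2N1C(=O)c1cccc(Cl)c1` gives 797 nM
Compound 2: `CC(=O)N1c2ccccc2CCC1C(=O)Nc1cc(C(F)(F)F)cc(C(F)(F)F)c1` gives > 70000 nM
Compound 3: `CCCCCCCCC(=O)N1c2ccccc2CCC1C(=O)Nc1ccccc1O` gives 38400 nM

Of the compounds shown here, three have been measured in a functional assay on HCT-15 cells (Homo sapiens) for cytotoxicity, read by sulforhodamine B assay, with a stated time of 72 h; a lower number here means a stronger inhibitor of growth, a higher number a weaker inhibitor of growth. Compound 1 gives 797 nM and compound 3 gives 38400 nM. For compound 2 the assay reports only a limit, > 70000 nM, so compound 2 stands at the limit of > 70000 nM in this assay, at which 1 of the 3 values shown sits, rather than at a number. Compound 4 `O=C(Nc1cc(C(F)(F)F)cc(C(F)(F)F)c1)C1CCc2ccccc2N1C(=O)c1ccccc1` is not yet measured and differs from compound 2 in one place: phenyl in place of methyl on a carbonyl carbon. Within the data shown here, no two measured compounds differ in a single place, so no measured step guides the expectation directly. Since compound 2 sits at the limit, only a step toward stronger growth inhibition can be resolved, and a step beyond the scatter in that direction is expected, an at least 5.8-fold lower number from compound 2 to compound 4 (0.76 log units; beyond the scatter). Compound 4 is estimated at 12000 nM, between 2500 nM and 70000 nM.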

Compound 4, concentration for 50% growth inhibition: 3540 nM
Compound 4: middle estimate off by 3.4-fold (0.53 log units), on the high side; low and high end bracket the measured number.
By their numbers in this assay, from the lowest: compound 1; then compound 4; then compound 3. At a limit, above all of these: compound 2.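

In this assay, phenyl in place of methyl on a carbonyl carbon gives an at least 19-fold lower number from compound 2 to compound 4 (1.29 log units; beyond the scatter). This is the only single change shown, and it establishes that the group on this carbonyl carbon, whose other neighbour is an amide-type nitrogen in a ring, can by itself bring growth inhibition into the measurable range. The value for compound 2 is a limit and not a number: the limit of > 70000 nM in this assay, at which 1 of the 4 values shown sits.

The compounds shown leave open whether an aromatic ring is needed here or whether cyclohexyl would serve as well. They also do not show how an amine or a carboxylic acid on the phenyl would change the value of compound 4.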